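Small sulfonamide changes and a dichlorophenyl test

A few compounds are considered here, and "the series" means these few. Any claim that something is new, unique, unknown or untested is made for them only; others in the source may bear on it.

Compound 1 `CCCN(CCC)c1c([N+](=O)[O-])cc(S(=O)(=O)Nc2ccc(OC)cc2)cc1[N+](=O)[O-]`: 31000 nM
Compound 2 `CCCN(CCC)c1c([N+](=O)[O-])cc(S(=O)(=O)Nc2ccc(C)cc2)cc1[N+](=O)[O-]`: 21000 nM
Compound 3 `CCCN(CCC)c1c([N+](=O)[O-])cc(S(=O)(=O)Nc2cccc(C)c2)cc1[N+](=O)[O-]`: 25000 nM

All three compounds were measured in a functional assay on PC-3 cells (Mus musculus) for cytotoxicity against PC-3 (Homo sapiens); on this read-out higher numbers stand for weaker inhibition and lower numbers for stronger inhibition. They share one core and differ only in the aromatic ring on the sulfonamide nitrogen. Compound 1, at 31000 nM, cannot be told apart from the other two, since its steps to both lie within the scatter.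

The next compound, compound 4 `CCCN(CCC)c1c([N+](=O)[O-])cc(S(=O)(=O)Nc2ccc(Cl)c(Cl)c2)cc1[N+](=O)[O-]`, has 3,4-dichlorophenyl in place of 4-methoxyphenyl on a sulfonamide nitrogen.

Going by the values given here, three measured steps bear on this change. Replacing the methoxy group gave a 1.5-fold lower number from compound 1 to compound 2 (0.17 log units; within the scatter), and swapping the whole ring gave a 1.2-fold lower number from compound 1 to compound 3 (0.09 log units; within the scatter). Moving the methyl group gave a 1.2-fold higher number from compound 2 to compound 3 (0.08 log units; within the scatter). All three are small, so this part of the molecule has so far shown little effect on the read-out. However, no measured compound carries chlorine, and the new ring differs more from these rings than they differ from one another.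

The expected result is no step beyond the scatter, with a slight lean towards a lower number: a 1.7-fold lower number from compound 1 to compound 4 (0.24 log units; within the scatter). For compound 4 the estimated value is 18000 nM, with an expected range from 7000 nM to 40000 nM.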

Compound 4, half-maximal inhibitory concentration: 15000 nM
The estimate for compound 4 lay 1.2-fold (0.08 log units) above the measured number, and the stated range covers the measured number.
By their numbers in this assay, from the lowest: compounds 4, 2, 3 and 1 (each within the scatter of the next, the first and the last beyond it).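

In this assay, going by these compounds alone, the 3,4-dichlorophenyl ring gives the first step at the sulfonamide nitrogen that lies beyond the scatter, a 2.1-fold lower number from compound 1 to compound 4 (0.32 log units; beyond the scatter), so changing the ring here can move the read-out, if only modestly. That step appears only against the 4-methoxyphenyl ring of compound 1: the comparisons with the two methyl-bearing rings, a 1.7-fold lower number from compound 3 to compound 4 (0.22 log units; within the scatter) and a 1.4-fold lower number from compound 2 to compound 4 (0.15 log units; within the scatter), stay within the scatter, so compound 4 cannot be ranked ahead of compound 2 or compound 3. The compounds shown come with no other measurement that could explain the step, so the numbers describe what happened but not why.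

As far as these compounds go, whether the step needs both chlorine atoms remains open, as does the effect of an amine or a carboxylic acid on this ring, or of a longer chain in place of the ring. All four compounds also share the same core, so these results say nothing about how changes elsewhere in the molecule would affect the read-out.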